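Mirror Image of a Strong Antiproliferative Lactone

The compounds below may be only part of what the source reports. "The series", "measured", "known", "first", "only" and "open" are said of these compounds alone.

Compound 1 `O=C1C[C@@H]2O[C@@H](Cc3ccccc3)[C@@H](O)[C@@H]2O1` was tested in a functional assay on K562 cells (Homo sapiens) for antiproliferative activity, read by MTT assay, with a stated time of 72 h (on this read-out higher numbers stand for weaker inhibition and lower numbers for stronger inhibition), and gave 20 nM. Among the three compounds measured, this is the lowest number, meaning the strongest inhibition of cell growth. Compound 2 `O=C1C[C@H]2O[C@H]([C@H](O)c3ccccc3)[C@H](O)[C@H]2O1` gives 410 nM in this assay, and compound 3 `O=C1C[C@@H]2O[C@H]3[C@H](c4ccccc4)c4ccccc4CO[C@H]3[C@@H]2O1` gives 1210 nM; both gaps to compound 1 lie well beyond the usual scatter of repeated measurements, so compound 1 is clearly the most potent of the three.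

Compound 4 `O=C1C[C@H]2O[C@H](Cc3ccccc3)[C@H](O)[C@H]2O1` has not yet been measured. It is built from exactly the same atoms and bonds as compound 1, and the only difference is the handedness of its ring carbons: the two compounds have the same atoms and bonds and differ only in configuration as drawn: 4 of 4 stereo elements differ (all stereocentres are inverted: mirror images); a stereocentre at a saturated ring carbon is drawn S in compound 1 and R in compound 4; a stereocentre at a saturated ring carbon is drawn S in compound 1 and R in compound 4; a stereocentre at a saturated ring carbon is drawn R in compound 1 and S in compound 4; a stereocentre at a saturated ring carbon is drawn S in compound 1 and R in compound 4. In other words, compound 4 is the mirror image of compound 1.

For the measured compounds named here, no measured pair here shows how swapping a compound for its mirror image changes the number, so the expected step rests on general experience rather than on these data. For many natural-product-like lactones, the mirror image is a noticeably weaker inhibitor, though occasionally both forms behave alike. On that basis the step of a 6.0-fold higher number from compound 1 to compound 4 (0.78 log units; beyond the scatter) is estimated to go toward a higher number, most likely beyond the scatter. Compound 4 is therefore expected to give about 120 nM in this assay, with a plausible range from 20 nM to 1200 nM.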

Compound 4, half-maximal inhibitory concentration: 510 nM
Compound 4: the middle estimate sits 4.3-fold (0.63 log units) below what was measured; the range from low to high includes it.
By their numbers in this assay, from the lowest: compound 1; then compounds 2 and 4 (each within the scatter of the next); then compound 3.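

In this assay, inverting every stereocentre while keeping all atoms and bonds in place gives a large step, a 26-fold higher number from compound 1 to compound 4 (1.41 log units; beyond the scatter), so the three-dimensional arrangement of this scaffold strongly affects its antiproliferative potency. Because nothing else separates this pair, the loss of potency can be traced to configuration alone: the fact that compounds 1 and 4 differ only in the configuration as drawn. By contrast, hydrogen in place of hydroxy on a saturated chain carbon bound to an aromatic carbon and a saturated ring carbon gives a 1.2-fold higher number from compound 2 to compound 4 (0.09 log units; within the scatter), so in this pair the change makes no difference that can be told from scatter.

All four stereocentres change together between compound 1 and compound 4, so the compounds shown cannot say which of them matter most, or whether inverting only one would cost as much potency. As far as these compounds go, it also remains open how a hydroxy on that chain carbon would behave with the configuration of compound 1, and whether an amine there or a longer chain leading to the phenyl ring would keep the potency of compound 1.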